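A few compounds are considered here, and "the series" means these few. Any claim that something is new, unique, unknown or untested is made for them only; others in the source may bear on it.

Measured compounds:
- Compound 1 `CC(=O)SCCC(CCCCC(=O)O)SC(C)=O` gives 11% of inhibition
- Compound 2 `CC(=O)SCCC(CCCCC(=O)Nc1ccccc1Cl)SC(C)=O` gives 15.2% of inhibition

Both numbers come from a functional assay on NCI-H460 cells (Homo sapiens) for inhibition, read by MTT assay, with a stated time of 24 h, tested at 100 ug/mL (on this read-out higher numbers stand for more inhibition of growth at the one concentration tested and lower numbers for less inhibition of growth), and nothing else has been measured there so far. Compound 2 gives 15.2% and stands within the scatter of compound 1, so the two cannot be ranked.

The next compound is compound 3 `CC(=O)SCCC(CCCCC(=O)Nc1cccc(Cl)c1)SC(C)=O` which has the same atoms as compound 2, joined differently, with 3-chlorophenyl in place of 2-chlorophenyl on an amide-type nitrogen. Going by the values given here, no measured pair swaps these two groups, so the data offer no direct guide. Among the compounds with values here, the one measured step bears on it only indirectly. That step is a number 4.2 percentage points higher from compound 1 to compound 2 (within the scatter) for (2-chlorophenyl)amino in place of hydroxy on a carbonyl carbon, and even this larger change of structure stays within the scatter. A step beyond the scatter in this assay is therefore not expected here. The estimate is a number 0.2 percentage points lower from compound 2 to compound 3 (within the scatter) as an expected step, with no direction to be told. Compound 3 is expected at 15% with an estimated range from 6% to 27% in this measurement.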

Compound 3, percent growth inhibition at one concentration: 42.8%
Beside the measured number, compound 3's estimate is 27.8 percentage points below it; measured number outside the range, above it.
By their numbers in this assay, from the lowest: compounds 1 and 2 (each within the scatter of the next); then compound 3.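

Moving the chlorine on the phenyl ring, with 3-chlorophenyl in place of 2-chlorophenyl on an amide-type nitrogen, gives a number 27.6 percentage points higher from compound 2 to compound 3 (beyond the scatter) in this assay, so two compounds with the same atoms can be told apart by where that one atom sits. It also changes how the amide reads against the carboxylic acid: the change from hydroxy to (2-chlorophenyl)amino gave only a number 4.2 percentage points higher from compound 1 to compound 2 (within the scatter), whereas the change to (3-chlorophenyl)amino gives a number 31.8 percentage points higher from compound 1 to compound 3 (beyond the scatter), so replacing hydroxy on the carbonyl carbon has no single effect across these compounds and its size depends on the group that enters. The data shown offer no independent measurement that could explain this difference between the two chlorophenyl groups.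

Going by these compounds, it remains open whether chlorine itself matters or whether other groups, such as 3-bromophenyl, 3-methoxyphenyl or plain phenyl, would give a similar number on the same nitrogen. On these data alone, it is also open whether the order of compound 2 and compound 3 would hold at other concentrations, as each has a single reading at one concentration.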